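This account rests on a few compounds, and the source may have more. Where it says the series, first, only, none or still open, it means among the compounds named here.

Compound 1 `O=S(=O)(Nc1ccc(-c2nc3ccccc3o2)cc1)c1ccccc1Cl`: > 100000 nM
Compound 2 `O=S(=O)(Nc1ccc(-c2nc3ccccc3o2)cc1)c1cccc(Cl)c1`: > 100000 nM
Compound 3 `O=S(=O)(Nc1ccc2oc(-c3ccccc3)nc2c1)c1cccc(Cl)c1`: 70000 nM

In an ADME assay on HEK293 cells (Homo sapiens) for cytotoxicity, read by resazurin assay, with a stated time of 48 h (a higher number here means that more compound is tolerated, a lower number that less compound is tolerated), compound 2 gives > 100000 nM, which is a limit of the assay and not a number. Compound 1 gives > 100000 nM, which is also a limit. The evidence so far is thin, with the limit of > 100000 nM in this assay, at which 2 of the 3 values shown sit. Compound 3 gives an actual number, 70000 nM.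

The next compound, compound 4 `C=Cc1ccc(S(=O)(=O)Nc2ccc(-c3nc4ccccc4o3)cc2)cc1`, has not been measured. It differs from compound 2 by 4-vinylphenyl in place of 3-chlorophenyl on a sulfonyl sulfur.

Within the data shown here, only one measured step changes this group, a step that the two limits leave unreadable from compound 1 to compound 2. With a limit at both ends, it has no readable size and gives no measured guide to the new change. The number for compound 3 70000 nM shows that a related compound can fall within the measurable range, so the expected range stays wide on the low side.

The estimated step is a number no higher from compound 2 to compound 4 (the limit leaves the size open), and no change beyond the usual scatter is expected. For compound 4 the expected value is 100000 nM, with an estimated range from 40000 nM to 200000 nM.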

Compound 4, half-maximal cytotoxic concentration: > 100000 nM
Compound 4: no number, only a limit; the forecaster's own chance of this, stated with the estimate: 65%; the middle value lies on the limit itself.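

In this assay compound 4 gives > 100000 nM, which is a limit and not a number. Among these compounds, no step among compound 1, compound 2 and compound 4 can be read, as all three values are limits. The compounds shown leave open whether the group on the sulfonyl sulfur affects tolerance at all.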